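The source may report more compounds than this note shows. Statements on the series, on what has been measured and on what is new or still open speak of the compounds shown alone.

In an assay on isolated protein for inhibition of annexin A2/S100-A10 (Homo sapiens), with a stated time of 5 min, tested at 50 uM (on this read-out higher numbers stand for more inhibition at the one concentration tested (going by the name of the read-out) and lower numbers for less inhibition), compound 2 `Cc1ccc(C(=O)C2=C(O)C(=O)N(CC(C)O)C2c2ccc(OC(F)(F)F)cc2)cc1` gives 110%. Its companion compound 1 `Cc1ccc(C(=O)C2=C(O)C(=O)N(CC(C)O)C2c2cccc(C(C)C)c2)cc1` in this assay gives 100%, and the two numbers lie within the usual scatter of each other, so no difference between them can be claimed. Compound 3 `Cc1ccc(C(=O)C2=C(O)C(=O)N(CC(C)O)C2c2ccc(C(F)(F)F)cc2)cc1` has not yet been measured. It differs from compound 2 in one place: trifluoromethyl in place of trifluoromethoxy on an aromatic carbon. Among the measured compounds shown here, no measured pair shows what such a change does here, so the expected step of a number 10 percentage points lower from compound 2 to compound 3 (within the scatter) is none beyond the scatter. Compound 3 is therefore expected to give 100%, within a range from 82% to 115%.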

Compound 3, a percentage reported as inhibition, at one concentration (the size of the read-out at that concentration, not a potency): 102%
Beside the measured number, compound 3's estimate is 2 percentage points below it; the range from low to high includes it.
By their numbers in this assay, from the lowest: compounds 1, 3 and 2 (each within the scatter of the next).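

In this assay, trifluoromethyl in place of trifluoromethoxy on the aromatic carbon gives a number 8 percentage points lower from compound 2 to compound 3 (within the scatter), so these two groups cannot be told apart here. Likewise, 4-(trifluoromethyl)phenyl in place of 3-isopropylphenyl on the saturated ring carbon gives a number 2 percentage points higher from compound 1 to compound 3 (within the scatter), so these two rings cannot be told apart either. Nothing available explains these results. From the compounds shown here alone, whether a smaller or very different group at that aromatic carbon, such as an amine or a carboxylic acid, would give a similar reading remains open. A single tested concentration also leaves the potency of these compounds open.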